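The source may hold more compounds than are shown below. What is called first, only, known or untested is meant among the compounds shown, and "the series" means these compounds.

Measured compounds in a functional assay on HCT-116 cells (Homo sapiens) for antiproliferative activity, read by MTT assay, with a stated time of 48 h; on this read-out lower numbers stand for stronger inhibition and higher numbers for weaker inhibition:
- compound 1 `COc1ccccc1-n1nncc1CN1C(=O)C2(C(C#N)=C(N)Oc3c2c2nc4ccccc4nc2c2ccccc32)c2ccccc21`: > 50000 nM
- compound 2 `CCOc1ccc(-n2nncc2CN2C(=O)C3(C(C#N)=C(N)Oc4c3c3nc5ccccc5nc3c3ccccc43)c3ccccc32)cc1`: > 50000 nM
- compound 3 `COc1ccccc1-n1nncc1CN1C(=O)C2(C(C#N)=C(N)Oc3c(N)cc4nc5ccccc5nc4c32)c2ccccc21`: > 50000 nM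

Three compounds share a spiro scaffold and were tested in this assay. In this assay compound 1 gives > 50000 nM, which is a limit of the assay and not a number. Compound 2 gives > 50000 nM, again only a limit. Compound 3 gives > 50000 nM, also a limit. The change from compound 1 to compound 2 is 4-ethoxyphenyl in place of 2-methoxyphenyl on an aromatic nitrogen, and the resulting step that the two limits leave unreadable from compound 1 to compound 2 cannot be sized because of the limit of > 50000 nM in this assay, at which 3 of the 3 values shown sit. How the core of compound 1 differs from the core of compound 3 is not broken down here.

Compound 4 `CCOc1ccc(-n2nncc2CN2C(=O)C3(C(C#N)=C(N)Oc4c(N)cc5nc6ccccc6nc5c43)c3ccccc32)cc1` has not yet been measured in this assay. Among the measured compounds shown here, it differs from compound 3 by 4-ethoxyphenyl in place of 2-methoxyphenyl on an aromatic nitrogen, the same change at the same place as the one from compound 1 to compound 2. Since compound 1 and compound 2 both sit at the limit, compound 4 is expected to behave like compound 3, with an estimated step of a number no higher from compound 3 to compound 4 (the limit leaves the size open). Compound 4 is therefore estimated at 50000 nM, within 20000 nM to 100000 nM, and most likely reported only as a limit.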

Compound 4, half-maximal inhibitory concentration: > 50000 nM
Compound 4 gave a limit, no number; the forecaster's own chance of this, stated with the estimate: 85%; the middle value lies on the limit itself.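

In this assay compound 4 gives > 50000 nM, which is a limit of the assay and not a number. No step can be read between compound 3 and compound 4, because both sit at the same limit: the limit of > 50000 nM in this assay, at which 4 of the 4 values shown sit.

The compounds shown leave open whether 4-ethoxyphenyl in place of 2-methoxyphenyl changes the read-out at all, and what the actual potency of any of the four compounds is.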